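The source may report more compounds than this note shows. Statements on the series, on what has been measured and on what is new or still open speak of the compounds shown alone.

Measured so far:
- compound 1, `CCc1oc2c(OC)cccc2c1C(=O)c1ccc(OC)cc1`: 17.2%
- compound 2, `CCc1cc2c(C(=O)c3ccc(OC)cc3)c(O)ccc2o1`: 28.7%
- compound 3, `CCc1cc2c(C(=O)c3ccc(O)cc3)c(O)ccc2o1`: 51.5%

The study reports three measured compounds in an assay for inhibition of solute carrier family 22 member 12 (Homo sapiens), read by scintillation counting, with a stated time of 60 min, tested at 50 uM (a higher number here means more inhibition at the concentration tested (going by the name of the read-out), a lower number less inhibition), and one that still awaits measurement. Compound 1 and compound 2 carry different cores; the difference between the two cores is not broken down here. In this assay compound 1 gives 17.2%, the lowest of the three numbers, and compound 2 gives 28.7%, a number beyond the scatter above it.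

Compound 3 differs from compound 2 in one place, (hydrogen in place of methyl on an oxygen on an aromatic ring). This change made a step of a number 22.8 percentage points higher from compound 2 to compound 3 (beyond the scatter), so that compound 3 reaches 51.5%.

Compound 4, `CCc1oc2c(O)cccc2c1C(=O)c1ccc(OC)cc1`, is built from compound 1 by the same change, (hydrogen in place of methyl on an oxygen on an aromatic ring). For the measured compounds named here, the place of the change reads the same in both pairs, so the step from compound 1 to compound 4 is taken as a repeat of the one seen from compound 2 to compound 3, though it starts from a different core and from a lower value. Because compound 1 gives 17.2% and the earlier change made a number 22.8 percentage points higher from compound 2 to compound 3 (beyond the scatter), compound 4 is expected to gain by about a number 20.8 percentage points higher from compound 1 to compound 4 (beyond the scatter) in this assay. Going by the values given here, the estimate for compound 4 is thus 38%, with a range from 22% to 55%, the width reflecting that only one earlier example of this change is available.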

Compound 4, a percentage reported as inhibition, at one concentration (the size of the read-out at that concentration, not a potency): 18.2%
Beside the measured number, compound 4's estimate is 19.8 percentage points above it; the measured number lies below the stated range.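

In this assay, the change from methoxy to hydroxy on the core of compound 1 came to a number 1 percentage points higher from compound 1 to compound 4 (within the scatter), so the gain seen on the other core did not carry over in size: the same change on two cores in this assay, a number 22.8 percentage points higher (beyond the scatter) from compound 2 to compound 3 and a number 1 percentage points higher (within the scatter) from compound 1 to compound 4, 21.8 percentage points apart, beyond the scatter of two such steps. Within these two pairs, then, the same named change cannot be treated as a fixed increment, and a step measured on the core of compound 2 gave a poor guide to the step on the core of compound 1. For the compounds shown here, what the result does not show is the reason for the gap, or whether it belongs to the core as a whole or to the surroundings of the oxygen that changes, as the two pairs differ in both and each core supplies only a single pair.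

The compounds shown leave open whether the other methoxy of compound 4, replaced by hydroxy, would give a step like the larger one on the other core. They also leave open how either core would respond to a carboxylic acid or an amine on an aromatic ring, or to a chain longer than the ethyl group that all four compounds carry.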